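The source may hold more compounds than are shown below. What is called first, only, known or untested is meant among the compounds shown, and "the series" means these compounds.

Of the compounds shown here, three have so far been measured in a functional assay on L1210 cells (Mus musculus) for cytotoxicity; on this read-out lower numbers stand for an effect already at smaller amounts and higher numbers for an effect only at larger amounts of compound. Compound 1 `COc1cc(C(C)O)c(OC)c2c1C(=O)C=CC2=O` gives 0.132 ug/mL in this assay, the lowest of the three numbers. Compound 3 `COc1ccc(OC)c2c1C(=O)C=C(C(C)O)C2=O` gives 0.487 ug/mL and compound 2 `CCCCCCC(O)C1=CC(=O)c2c(OC)ccc(OC)c2C1=O` gives 0.732 ug/mL; both numbers stand higher than that of compound 1 by more than the usual scatter, with compound 3 the nearer of the two and compound 2 the furthest away.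

Compound 4 `CCCCCCC(O)c1cc(OC)c2c(c1OC)C(=O)C=CC2=O` has not yet been measured in this assay. Compared with compound 1 it carries pentyl in place of hydrogen on a saturated chain carbon, two bonds along the chain from an aromatic carbon and an oxygen on a saturated carbon.

Among the measured compounds shown here, one measured step bears on this change. Between compound 2 and compound 3 the same group is removed rather than added, on a saturated chain carbon that sits two bonds along the chain from a double-bonded ring carbon rather than from an aromatic carbon: a 1.5-fold lower number from compound 2 to compound 3 (0.18 log units; within the scatter). That exchange of pentyl for hydrogen therefore moved the number only within the scatter. Read in the other direction, adding pentyl to compound 1 is expected to leave its number close to where it is, with perhaps a slight drift toward a higher number, so the expected step of a 1.5-fold higher number from compound 1 to compound 4 (0.18 log units; within the scatter) is small. Compound 4 is accordingly estimated at 0.2 ug/mL, within a range from 0.08 ug/mL to 0.5 ug/mL.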

Compound 4, concentration for half-maximal effect: 0.22 ug/mL
Compound 4: the middle estimate sits 1.1-fold (0.04 log units) below what was measured, within the range that was stated.
By their numbers in this assay, from the lowest: compounds 1 and 4 (each within the scatter of the next); then compounds 3 and 2 (each within the scatter of the next).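

In this assay the exchange of hydrogen for pentyl is now seen on a saturated chain carbon, two bonds along the chain from an aromatic carbon, and the step there is small: a 1.7-fold higher number from compound 1 to compound 4 (0.22 log units; within the scatter). The 1-hydroxyheptyl chain of compound 4 therefore reads like the 1-hydroxyethyl chain of compound 1 at this position. The earlier compounds showed this exchange only on a chain carried by a double-bonded ring carbon, whereas the same change can now be compared on two cores, and it reads alike on both: the same change on two cores in this assay, a 1.5-fold lower number (0.18 log units; within the scatter) from compound 2 to compound 3 and a 1.7-fold lower number (0.22 log units; within the scatter) from compound 4 to compound 1, 1.1-fold (0.04 log units) apart, within the scatter of two such steps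

As far as these compounds go, only hydrogen and pentyl have been compared on this carbon, so it remains open whether a longer chain such as decyl, a chain ending in an amine or a carboxylic acid, or a phenyl ring would also leave the number within the scatter. All the compounds shown also keep the oxygen on this saturated carbon, so the compounds shown do not tell how a ketone or a plain methylene there would read.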